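Swapping a Pyridine for an Aminopyrazine on a Fused Core

This account rests on a few compounds, and the source may have more. Where it says the series, first, only, none or still open, it means among the compounds named here.

Of the compounds shown here, two that share a large fused aromatic core have been tested in a functional assay, read by spectrophotometry, with a stated time of 30 min; a lower number here means a stronger inhibitor, a higher number a weaker inhibitor. Compound 1 `Cc1nc2c3ccccc3ccc2c2nc3c(ccc4ccccc43)c(-c3cccc([N+](=O)[O-])c3)c12` carries a 3-nitrophenyl group and gives 117 ug/mL. Compound 2 `Cc1nc2c3ccccc3ccc2c2nc3c(ccc4ccccc43)c(-c3cccnc3)c12` carries a pyridin-3-yl group at the same carbon and gives 98.2 ug/mL. Compound 2 stands at the low end of the two numbers, yet the step of a 1.2-fold lower number from compound 1 to compound 2 (0.08 log units; within the scatter) is within the scatter, so the two values cannot be told apart. Compound 3 `Cc1nc2c3ccccc3ccc2c2nc3c(ccc4ccccc43)c(-c3nccnc3N)c12` makes a further exchange at that same carbon: 3-aminopyrazin-2-yl in place of pyridin-3-yl on an aromatic carbon. Going by the values given here, the only measured step that bears on this change is a 1.2-fold lower number from compound 1 to compound 2 (0.08 log units; within the scatter), which also swapped one six-membered aromatic group for another there and stayed within the scatter. No step beyond the scatter is therefore expected in this assay. For compound 3 the estimate in this assay is 95 ug/mL, with a range from 45 ug/mL to 200 ug/mL. The expected step is a 1.0-fold lower number from compound 2 to compound 3 (0.01 log units; within the scatter).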

Compound 3, half-maximal inhibitory concentration: 81.7 ug/mL
Compound 3: the middle estimate sits 1.2-fold (0.07 log units) above what was measured, within the range that was stated.
By their numbers in this assay, from the lowest: compounds 3, 2 and 1 (each within the scatter of the next).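

The step to 3-aminopyrazin-2-yl brings a hydrogen-bond donor and two more hydrogen-bond acceptors to this carbon, yet in this assay it gives a 1.2-fold lower number from compound 2 to compound 3 (0.08 log units; within the scatter). Even the two groups furthest apart in their numbers, 3-nitrophenyl and 3-aminopyrazin-2-yl, give only a 1.4-fold lower number from compound 1 to compound 3 (0.16 log units; within the scatter), so all three groups shown at this carbon cannot be told apart. No measurement is available that would explain this flat result.

All three groups are six-membered aromatic rings, so the compounds shown say nothing about other kinds of group at this carbon. Going by these compounds, whether a carboxylic acid, a piperidine or a longer alkyl chain there would give a step beyond the scatter remains open.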